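Swapping the Fluorinated Hydrazone Arm for a Brominated One

This account rests on a few compounds, and the source may have more. Where it says the series, first, only, none or still open, it means among the compounds named here.

Within the data shown here, compound 1 `CCCSc1nc(N/N=C/c2ccccc2F)c2nnn(Cc3ccccc3)c2n1` is one of two compounds measured in a functional assay on ECa-109 cells (Homo sapiens) for antiproliferative activity, read by MTT assay, with a stated time of 72 h; on this read-out lower numbers stand for stronger inhibition and higher numbers for weaker inhibition. In this assay compound 1 gives only a limit, > 64000 nM, and no number. Compound 2 `C#CCSc1nc(N/N=C(\C)c2ccccc2O)c2nnn(Cc3ccccc3)c2n1` differs from compound 1 in more than one place. In this assay compound 2 gives 5250 nM. Compound 1 thus stands at the weak end of what has been measured, one of two values resting at the limit (the limit of > 64000 nM in this assay, at which 1 of the 2 values shown sits). Compound 3 `CCCSc1nc(N/N=C(\C)c2ccc(Br)cc2)c2nnn(Cc3ccccc3)c2n1` has not yet been measured; it differs from compound 1 by a group of 10 heavy atoms (8 carbon, 1 nitrogen, 1 bromine; one six-membered aromatic ring of carbon only) in place of a group of 9 heavy atoms (7 carbon, 1 nitrogen, 1 fluorine; one six-membered aromatic ring of carbon only), on a nitrogen on an aromatic ring. Among the measured compounds shown here, no step between measured compounds has been recorded, so the size of the change from compound 1 to compound 3 cannot be read off any neighbour pair. Given that compound 2 sits at 5250 nM in this assay, a gain that clears the usual scatter is expected. A value resting at the limit, as compound 1 does, remains possible. Compound 3 is expected to give 25000 nM, between 6000 nM and 64000 nM, a step of an at least 2.5-fold lower number from compound 1 to compound 3 (0.40 log units; beyond the scatter).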

Compound 3, half-maximal inhibitory concentration: 4670 nM
Estimate against measurement, compound 3: 5.4-fold (0.73 log units) above; the whole stated range lies above it.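

In this assay, the change on a nitrogen on an aromatic ring gives an at least 13-fold lower number from compound 1 to compound 3 (1.13 log units; beyond the scatter), which shows that the group carried at this place can by itself move the read-out from a limit to a measurable value. The rest of compound 1 stays as it is, and the two groups share one six-membered aromatic ring of carbon only, so the gain belongs to what differs within that group. Compound 1 gives only a limit, so this step is a bound and not an exact size: the limit of > 64000 nM in this assay, at which 1 of the 3 values shown sits.

The two groups differ in their carbon count as well as in fluorine and bromine, so the compounds shown cannot separate the halogen from the added carbon. They also leave open how the same group would read with chlorine, a methoxy group or an amine on its ring.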